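A few compounds are considered here, and "the series" means these few. Any claim that something is new, unique, unknown or untested is made for them only; others in the source may bear on it.

Three compounds share one core and differ at two ends. In a functional assay on MIA PaCa-2 cells (Homo sapiens) for inhibition, read by MTT assay, with a stated time of 7 days (on this read-out lower numbers stand for stronger inhibition and higher numbers for weaker inhibition), compound 1 `CC(C)S(=O)(=O)c1ccc(S(=O)(=O)N2CCC[C@@H](C(=O)N3CCC(F)(F)CC3)C2)cc1` gives 11 nM, and compound 2 `CCN(CC)C(=O)c1ccc(S(=O)(=O)N2CCC[C@@H](C(=O)N3CCC(F)(F)CC3)C2)cc1` gives 70 nM. Among the compounds with values here, the only measured step between them, a 6.4-fold higher number from compound 1 to compound 2 (0.80 log units; beyond the scatter), changes the group on the aromatic carbon and leaves the amide end untouched. Compound 3 `CCN(CC)S(=O)(=O)c1ccc(S(=O)(=O)N2CCC[C@@H](C(=O)N[C@H]3CC[C@@H](OC)CC3)C2)cc1` stands highest of the three numbers with 960 nM, beyond the scatter from both compound 2 and compound 1.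

Compound 4 `CCN(CC)S(=O)(=O)c1ccc(S(=O)(=O)N2CCC[C@@H](C(=O)N3CCC(F)(F)CC3)C2)cc1` has not yet been measured. It differs from compound 3 in one place: 4,4-difluoropiperidin-1-yl in place of (4-methoxycyclohexyl)amino on a carbonyl carbon. Within the data shown here, no measured step covers this change at the amide end, and the step of a 6.4-fold higher number from compound 1 to compound 2 (0.80 log units; beyond the scatter) concerns another place, so it gives no direct guide. Still, both compounds that carry the entering group give far lower numbers: compound 1 gives 11 nM and compound 2 gives 70 nM. The expected step is therefore a large drop, a 24-fold lower number from compound 3 to compound 4 (1.38 log units; beyond the scatter), and compound 4 is estimated at 40 nM, within a range from 10 nM to 200 nM.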

Compound 4, half-maximal inhibitory concentration: 16 nM
The estimate for compound 4 lay 2.5-fold (0.40 log units) above the measured number, and the stated range covers the measured number.
By their numbers in this assay, from the lowest: compounds 1 and 4 (each within the scatter of the next); then compound 2; then compound 3.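

In this assay, within the data shown here, changing only the amide end gives the first measured step at this position (a 60-fold lower number from compound 3 to compound 4 (1.78 log units; beyond the scatter)), a direct comparison of (4-methoxycyclohexyl)amino with 4,4-difluoropiperidin-1-yl. With 4,4-difluoropiperidin-1-yl held fixed, diethylsulfamoyl in place of diethylcarbamoyl on the aromatic carbon gives a further step (a 4.4-fold lower number from compound 2 to compound 4 (0.64 log units; beyond the scatter)), whereas diethylamino in place of isopropyl on the sulfonyl sulfur leaves the two compounds indistinguishable (a 1.5-fold higher number from compound 1 to compound 4 (0.16 log units; within the scatter)). Nothing available explains why the amide change has so large an effect.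

This change alters the amide hydrogen, the methoxy group and the fluorines all at once, so the compounds shown cannot separate their contributions. From the compounds shown here alone, how a plain piperidin-1-yl or a morpholin-4-yl would read on this carbonyl carbon remains open.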